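Methylamide to acid on the acrylic chain of compound 3

The source may hold more compounds than are shown below. What is called first, only, known or untested is meant among the compounds shown, and "the series" means these compounds.

Working notes on a small set of acrylamide-type inhibitors tested in an assay on a protein complex for inhibition of CDK8/Cyclin C (Homo sapiens), with a stated time of 1 h; on this read-out lower numbers stand for stronger inhibition and higher numbers for weaker inhibition. Compound 1 `CCOC(=O)/C=C/c1ccncc1-c1ccc2c(ccn2C)c1` carries an ethyl ester and gives 144 nM. Compound 2 `COc1ccc(-c2cnccc2/C=C/C(=O)N2CC(OC)C2)cc1OC`, an azetidine amide with a differently substituted aryl group, gives 1220 nM. Compound 3 `CNC(=O)/C=C/c1ccncc1-c1ccc2ccccc2c1`, the methylamide on a naphthyl-bearing core, gives 12.4 nM, the lowest number of the three; compound 1 sits far above it and compound 2 further still, both gaps beyond the scatter.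

The next step replaces the amide of compound 3: in compound 4 `O=C(O)/C=C/c1ccncc1-c1ccc2ccccc2c1` the change is hydroxy in place of methylamino on a carbonyl carbon. Going by the values given here, no pair in the measured set isolates this change, so the expectation rests on the general picture. For this assay the step of a 6.5-fold higher number from compound 3 to compound 4 (0.81 log units; beyond the scatter) is expected to be a loss of potency of moderate size, beyond the scatter. Compound 4 is therefore estimated at 80 nM, with a plausible range from 15 nM to 400 nM.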

Compound 4, half-maximal inhibitory concentration: 5 nM
Compound 4: the middle estimate sits 16-fold (1.20 log units) above what was measured; measured number outside the range, below it.
By their numbers in this assay, from the lowest: compound 4; then compound 3; then compound 1; then compound 2.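

In this assay, going by these compounds alone, a 2.5-fold lower number from compound 3 to compound 4 (0.39 log units; beyond the scatter) is the first reading at this carbonyl carbon in which nothing else changes, since compounds 1 and 2 differ from compound 3 in more than one place. It shows that the methylamino group is not required for a low number here: hydroxy, with one heavy atom in place of two and the same printed count of hydrogen-bond donors, gives a modest step in the favourable direction, beyond the scatter. No supporting data are available to explain this step.

As far as these compounds go, whether the gain belongs to the carboxy group specifically remains open, as a primary carboxamide, a methyl ester or a tetrazole on the core of compound 3 would be needed to show it. From the compounds shown here alone, it is also open whether the same change would give a step of similar size on the aryl groups of compound 1 or compound 2.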